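The source may report more compounds than this note shows. Statements on the series, on what has been measured and on what is new or still open speak of the compounds shown alone.

The series gathers three measured compounds and one that still awaits measurement. Compound 1 `C=CCn1ncc2c(C)nc(CC)n2c1=O` was tested in a functional assay for inhibition, with Homo sapiens as the target; a higher number here means a weaker inhibitor, a lower number a stronger inhibitor; in this assay compound 1 returns only a limit of the assay, > 48000 nM. Compound 2 `Cc1nc(C)n2c(=O)n(C)ncc12` likewise gives only a limit in this assay, > 48000 nM. Compound 3 `COCc1ncc2n1C(NCCN(C)C)NN=C2NCCN(C)C` also stops at a limit in this assay, > 48000 nM. Where compound 2 stands can therefore be said only in terms of the limit of > 48000 nM in this assay, at which 3 of the 3 values shown sit: its result is a limit, not a number, and the same holds for the two other values shown. Among the measured compounds shown here, no step between measured compounds differing in one place is available, so no measured change in potency can be read from these three.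

Compound 4 `C=CCn1ncc2c(C)nc(C)n2c1=O` differs from compound 2 by vinyl in place of hydrogen on a saturated chain carbon bound to an aromatic nitrogen. With every measured value sitting at the limit, the author expects no step beyond the scatter in this assay for the change from compound 2 to compound 4, a step that the limit leaves unreadable from compound 2 to compound 4, and expects compound 4 to show 60000 nM, within a range of 20000 nM to 200000 nM.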

Compound 4, half-maximal inhibitory concentration: 73000 nM
Compound 4: middle estimate off by 1.2-fold (0.09 log units), on the low side; the range from low to high includes it.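

Neither step to compound 4, from compound 2 or from compound 1, can be read in this assay, because each of those two compounds gives only a limit: the limit of > 48000 nM in this assay, at which 3 of the 4 values shown sit.

The compounds shown leave open how far compound 4 stands from compound 1 and compound 2 in this assay.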